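Benzyl(methyl)amino Variant of Compound 1 in the Series

This account rests on a few compounds, and the source may have more. Where it says the series, first, only, none or still open, it means among the compounds named here.

Compound 1 `Cc1cc(NC(C)C)nc(SCc2nc3ccccc3[nH]2)n1` is the reference point. In a functional assay on MGC-803 cells (Homo sapiens) for cytotoxicity, read by MTT assay, with a stated time of 72 h (on this read-out lower numbers stand for stronger inhibition and higher numbers for weaker inhibition), compound 1 reaches only the limit > 100000 nM, so its standing among the three measured compounds is known only as far as that limit allows. Compound 2 `Cc1cc(N2CCNCC2)nc(SCc2nc3ccccc3[nH]2)n1` likewise gives only the limit > 100000 nM in this assay. Among the compounds with values here, compound 3 `COc1ccccc1Nc1cc(C)nc(SCc2nc3ccccc3[nH]2)n1` is the single measured compound with a number in this assay, 56200 nM. The step that the two limits leave unreadable from compound 1 to compound 2 is therefore not readable, while an at least 1.7-fold lower number from compound 1 to compound 3 (0.25 log units; that floor lies within the scatter) and an at least 1.7-fold lower number from compound 2 to compound 3 (0.25 log units; that floor lies within the scatter) give floors that sit within the scatter. Two of the three values sit at the limit of > 100000 nM in this assay, at which 2 of the 3 values shown sit.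

Compound 4 `Cc1cc(N(C)Cc2ccccc2)nc(SCc2nc3ccccc3[nH]2)n1` differs from compound 1 in one place: benzyl(methyl)amino in place of isopropylamino on an aromatic carbon. Within the data shown here, the step of an at least 1.7-fold lower number from compound 1 to compound 3 (0.25 log units; that floor lies within the scatter) bears on it most closely, since there too an aromatic ring replaces the isopropyl group on the amino nitrogen; compound 4, however, carries the benzyl(methyl)amino group with no hydrogen-bond donor, and no measured pair covers that part of the change. Among the measured compounds shown here, since the only readable comparison gives a floor within the scatter, no step beyond the scatter is expected, and a limit is again possible. The expected step is an at least 1.4-fold lower number from compound 1 to compound 4 (0.15 log units; that floor lies within the scatter). Compound 4 is estimated at 70000 nM, with a range from 25000 nM to 200000 nM.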

Compound 4, half-maximal inhibitory concentration: 31300 nM
For compound 4 the middle estimate is 2.2-fold (0.35 log units) above the measured one; the measured number falls inside the stated range.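

In this assay, this position now shows its first changes beyond the scatter: an at least 3.1-fold lower number from compound 1 to compound 4 (0.50 log units; beyond the scatter), and an at least 3.1-fold lower number from compound 2 to compound 4 (0.50 log units; beyond the scatter). Against the anilino-type group the picture differs, with a 1.8-fold lower number from compound 3 to compound 4 (0.25 log units; within the scatter), so compound 3 and compound 4 cannot be ordered, and a benzyl(methyl)amino group, with 0 hydrogen-bond donors, gives a measured number here just as the (2-methoxyphenyl)amino group does. Both compounds with a measured number carry a six-membered aromatic ring of carbon on the amino nitrogen, while the steps from compound 1 and compound 2 are floors only, their values being limits of the assay and not numbers: the limit of > 100000 nM in this assay, at which 2 of the 4 values shown sit.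

As far as these compounds go, how much of the step belongs to the benzyl group and how much to the methyl on the nitrogen stays open; a benzylamino group and a dimethylamino group at this place would separate the two. Also open, from the compounds shown here alone, is whether a longer chain between the nitrogen and the phenyl ring, such as a phenethyl group, would move the number beyond the scatter relative to compound 4.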